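A few compounds are considered here, and "the series" means these few. Any claim that something is new, unique, unknown or untested is made for them only; others in the source may bear on it.

Of the compounds shown here, three of one series have been measured in an ADME assay (Rattus norvegicus, strain Wistar Han) for pharmacokinetics; a lower number here means that more of the compound stays in the plasma, a higher number that more of the compound sits outside the plasma. Compound 1 `CCn1c(-c2cnc(C)nc2)nc2c(O[C@H]3CCN(C(=O)C4CC4)C3)ncnc21` gives 2.8 L/kg in this assay. Compound 2 `CCn1c(-c2cnc(C)nc2)nc2c(N[C@H]3CCN(C(=O)C4CCOC4)C3)ncnc21` gives 2.3 L/kg in this assay. Compound 3 `CCn1c(-c2ccc(C(F)(F)F)nc2)nc2c(O[C@H]3CCN(C(=O)[C@H]4C[C@@H](OC)C4)C3)ncnc21` gives 1.3 L/kg in this assay. Compound 2 thus sits between the other two numbers, but its gap to compound 1 and its gap to compound 3 both lie within the usual scatter of such measurements, so the three cannot be ranked on these data.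

The unmeasured compound 4 `CCC(=O)N1CC[C@H](Nc2ncnc3c2nc(-c2cnc(C)nc2)n3CC)C1` is reached from compound 2 by a single change at the acyl group on the ring nitrogen: ethyl in place of oxolan-3-yl on a carbonyl carbon. Among the measured compounds shown here, no measured pair shows this same change, so its effect in this assay can only be guessed from the spread of the three values.

Compound 4 is expected to stay close to compound 2, with an estimated step of a 1.2-fold higher number from compound 2 to compound 4 (0.09 log units; within the scatter) that does not exceed the scatter. The value of compound 4 in this assay is estimated at 2.8 L/kg, with a range from 1.6 L/kg to 4.8 L/kg.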

Compound 4, volume of distribution: 3.6 L/kg
Compound 4: middle estimate off by 1.3-fold (0.11 log units), on the low side; measured number inside the range.
By their numbers in this assay, from the lowest: compounds 3, 2, 1 and 4 (each within the scatter of the next, the first and the last beyond it).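

Among the compounds shown here, the first matched change at the acyl group on the ring nitrogen, ethyl in place of oxolan-3-yl on a carbonyl carbon, reads in this assay as a 1.6-fold higher number from compound 2 to compound 4 (0.19 log units; within the scatter) for this swap of (oxolan-3-yl)carbonyl to propanoyl. On this one pair, then, the ring and its oxygen can give way to the smaller, open ethyl without a step in volume of distribution that stands clear of the scatter. No measurement among the data speaks to what lies behind this step.

What the compounds shown leave open is how a carbonyl substituent carrying an amine, a carboxylic acid or a longer chain would read in this assay against compound 2. A single pair also cannot tell whether the same change would read alike on a compound with other groups around the shared core.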